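Fluoro for Methyl: From Compound 3 to Compound 4

This account rests on a few compounds, and the source may have more. Where it says the series, first, only, none or still open, it means among the compounds named here.

Four close relatives share one core and differ only in small substituents. In a functional assay, with a stated time of 150 min, tested at 35 ug/mL (on this read-out lower numbers stand for a weaker effect and higher numbers for a stronger effect at the one concentration tested), compound 1 `COC(=O)c1c(Nc2ccc(F)cc2)sc(C(=O)c2ccc(C)cc2)c1C` is reported as "not active" (no number reported) and compound 3 `Cc1ccc(Nc2sc(C(=O)c3ccc(C)cc3)c(C)c2C(=O)O)cc1` is reported as "not active" (no number reported), so no number stands for either, and compound 3 sits among the entries without a value. Compound 2 `COc1ccc(C(=O)c2sc(Nc3ccc(F)cc3)c(C(=O)O)c2C)cc1` gives 12.8% in this assay, a weak effect. Going by these compounds, compound 4 `Cc1ccc(C(=O)c2sc(Nc3ccc(F)cc3)c(C(=O)O)c2C)cc1` is untested and differs from compound 3 in one place: fluoro in place of methyl on an aromatic carbon. For the measured compounds named here, no measured pair shows how large such a change is here, and nothing points to a strong effect. Compound 2 gives 12.8%, a weak effect, and compound 3 gives "not active" (no number reported) with no number reported, so the estimate for compound 4 is 10%, with an expected range from 0% to 25%.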

Compound 4, a percentage reported as activity, at one concentration (the size of the read-out at that concentration, not a potency): "not active" (no number reported)
Nothing numeric was reported for compound 4, and the estimate cannot be compared.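

Neither compound 3 nor compound 4 carries a number, so no step between them can be read, and no other measurement offers an explanation. The compounds shown leave open how much fluoro in place of methyl changes the effect.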